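Swapping indazole for benzothiophene at one aromatic carbon

The compounds below may be only part of what the source reports. "The series", "measured", "known", "first", "only" and "open" are said of these compounds alone.

Measured in an ADME assay (liver) for metabolic stability, with Liver microsome (Homo sapiens) as the target, using microsomes and NADPH, with a stated time of 30 min, tested at 1 uM; a higher number here means faster removal of the compound, a lower number slower removal:
Compound 1 `Nc1ccc(S(=O)(=O)N2CCN(c3ncc(C(O)(C(F)(F)F)C(F)(F)F)cc3-c3cccc(F)c3)CC2)cn1`: 25 mL.min-1.g-1
Compound 2 `Nc1ccc(S(=O)(=O)N2CCN(c3ncc(C(O)(C(F)(F)F)C(F)(F)F)cc3-c3ccc4[nH]ncc4c3)CC2)cn1`: 27 mL.min-1.g-1

For the measured compounds named here, compound 2 stands level with compound 1, the only other measured compound, as their two values lie within the usual scatter of each other. Compound 3 `Nc1ccc(S(=O)(=O)N2CCN(c3ncc(C(O)(C(F)(F)F)C(F)(F)F)cc3-c3cc4ccccc4s3)CC2)cn1` has not yet been measured and differs from compound 2 in one place: 1-benzothiophen-2-yl in place of 1H-indazol-5-yl on an aromatic carbon. Here 1-benzothiophen-2-yl comes in place of 1H-indazol-5-yl on an aromatic carbon, ortho to a large group.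

Going by the values given here, only one measured step bears on this change. It is a 1.1-fold higher number from compound 1 to compound 2 (0.03 log units; within the scatter), and it also exchanges the group on an aromatic carbon. Among the compounds with values here, that step is small, but it is a single example, and no measured compound carries 1-benzothiophen-2-yl. The data therefore fix no direction for the new step, and a large one would not be a surprise. A slight upward lean is a matter of judgement only. The step expected in this assay is a 1.3-fold higher number from compound 2 to compound 3 (0.11 log units; within the scatter), and this expectation is held loosely. Compound 3 is estimated at 35 mL.min-1.g-1, with an expected range of 18 mL.min-1.g-1 to 70 mL.min-1.g-1.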

Compound 3, intrinsic clearance in microsomes: < 14 mL.min-1.g-1
Compound 3 gave a limit, no number (the forecaster's own chance of this, stated with the estimate: 3%); middle value at least 2.5-fold (0.39 log units) from the limit.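

In this assay compound 3 stands as a limit of the assay and not as a number: the limit of < 14 mL.min-1.g-1 in this assay, at which 1 of the 3 values shown sits. The earlier exchange at this aromatic carbon, ortho to a large group, gave only a step within the scatter, whereas 1-benzothiophen-2-yl now gives an at least 1.9-fold lower number from compound 2 to compound 3 (0.28 log units; that floor lies within the scatter) and an at least 1.7-fold lower number from compound 1 to compound 3 (0.25 log units; that floor lies within the scatter). The position is thus not shown to be indifferent to the group it carries, and the direction of both new steps is downward, though only their floors are fixed and the full size of neither can be read.

The compounds shown do not separate the change of ring atoms from the change of attachment point, as 1-benzothiophen-2-yl differs from 1H-indazol-5-yl in both, so a 1-benzothiophen-5-yl group or a 1H-indol-2-yl group would be needed to tell these apart. As far as these compounds go, whether the lower reading belongs to the benzothiophene alone or extends to other fused rings such as benzofuran-2-yl also stays open, as does the true value of compound 3 beneath its limit.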